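The source may report more compounds than this note shows. Statements on the series, on what has been measured and on what is new or still open speak of the compounds shown alone.

Among the compounds with values here, in a functional assay on K562 cells (Homo sapiens) for inhibition, read by trypan blue exclusion, with a stated time of 72 h (on this read-out higher numbers stand for weaker inhibition and lower numbers for stronger inhibition), the three measured members differ only in the group on a nitrogen on an aromatic ring. Compound 1 `Cn1c(=O)c(S(=O)(=O)c2ccc(F)cc2F)cc2cnc(Nc3ccccn3)nc21` stands at 35000 nM, compound 2 `Cn1c(=O)c(S(=O)(=O)c2ccc(F)cc2F)cc2cnc(Nc3ccc4cccc(O)c4n3)nc21` at 5000 nM and compound 3 `Cc1cc2cc(Nc3ncc4cc(S(=O)(=O)c5ccc(F)cc5F)c(=O)n(C)c4n3)ccc2[nH]1` at 750 nM, the lowest number of the three.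

Next is compound 4 `Cn1c(=O)c(S(=O)(=O)c2ccc(F)cc2F)cc2cnc(Nc3ccc4c(c3)C(=O)C(=O)N4)nc21`, with this change from compound 3: a group of 11 heavy atoms (8 carbon, 1 nitrogen, 2 oxygen; one five-membered non-aromatic ring with 1 hetero atom, one six-membered aromatic ring of carbon only) in place of a group of 10 heavy atoms (9 carbon, 1 nitrogen; one five-membered aromatic ring with 1 hetero atom, one six-membered aromatic ring of carbon only), on a nitrogen on an aromatic ring. The six-membered aromatic ring of carbon only stays, while the five-membered aromatic ring gives way to a five-membered non-aromatic ring.

Within the data shown here, no measured step makes this exact change, so the evidence is indirect. Replacing pyridin-2-yl with 2-methyl-1H-indol-5-yl gave a 47-fold lower number from compound 1 to compound 3 (1.67 log units; beyond the scatter), which is large. Replacing pyridin-2-yl with 8-hydroxyquinolin-2-yl gave a 7.0-fold lower number from compound 1 to compound 2 (0.85 log units; beyond the scatter), and replacing that group with 2-methyl-1H-indol-5-yl gave a 6.7-fold lower number from compound 2 to compound 3 (0.82 log units; beyond the scatter), both modest. All three steps show that this group matters in this assay. Having two rings is no guarantee of a low number, as compound 2 also carries two rings and stands at 5000 nM. With compound 3 the lowest so far, a move to a higher number is the likelier direction.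

The expected step is a 2.7-fold higher number from compound 3 to compound 4 (0.43 log units; beyond the scatter), a modest one. Compound 4 is estimated at 2000 nM, with an expected range of 400 nM to 10000 nM.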

Compound 4, half-maximal inhibitory concentration: 30000 nM
For compound 4 the middle estimate is 15-fold (1.18 log units) below the measured one, outside the stated range (above it).
By their numbers in this assay, from the lowest: compound 3; then compound 2; then compounds 4 and 1 (each within the scatter of the next).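

In this assay, the six-membered aromatic ring of carbon only stays while the five-membered aromatic ring gives way to a five-membered non-aromatic ring with 2 double bonds outside aromatic rings, and this single change gives a large step (a 40-fold higher number from compound 3 to compound 4 (1.60 log units; beyond the scatter)). The low number of compound 3 therefore does not follow from the carbon ring alone, and the five-membered part of the group on this nitrogen carries much of the difference in this series. The new group also compares poorly with 8-hydroxyquinolin-2-yl (a 6.0-fold higher number from compound 2 to compound 4 (0.78 log units; beyond the scatter)), while against the single ring of pyridin-2-yl it gives no separation (a 1.2-fold lower number from compound 1 to compound 4 (0.07 log units; within the scatter)), so a second ring does not by itself set a compound apart from compound 1, and compound 4 goes against any reading of two-ring groups as generally better. Nothing at hand explains the size of these steps.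

On these data alone, it remains open whether 1H-indol-5-yl without the methyl, or a five-membered non-aromatic ring with a single carbonyl, would stand nearer compound 3 or compound 4. As far as these compounds go, it is equally open how a group carrying an amine or a carboxylic acid on this nitrogen would read in this assay.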